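The source may hold more compounds than are shown below. What is called first, only, known or untested is meant among the compounds shown, and "the series" means these compounds.

Measured compounds:
Compound 1, `COc1ccc2ncc(S(=O)(=O)c3ccc(C)c(Cl)c3)c(N3CCC(C)CC3)c2c1`, gives 85%.
Compound 2, `Cc1ccc2ncc(S(=O)(=O)c3ccc(C)c(Cl)c3)c(N3CCC(C)CC3)c2c1`, gives 91%.
Compound 3, `Cc1ccc(S(=O)(=O)c2cnc3ccc(Cl)cc3c2N2CCC(C)CC2)cc1Cl`, gives 81%.

All three were tested in an assay on isolated protein for displacement of a labelled ligand from metabotropic glutamate receptor 5 (Homo sapiens), with a stated time of 60 min, tested at 1 uM; a higher number here means more inhibition at the concentration tested (going by the name of the read-out), a lower number less inhibition. Compound 1 stands second highest of the three numbers, with compound 3 nearest, a number 4 percentage points lower from compound 1 to compound 3 (within the scatter), and compound 2 furthest, a number 6 percentage points higher from compound 1 to compound 2 (within the scatter); both steps lie within the scatter, as does the step of a number 10 percentage points lower from compound 2 to compound 3 (within the scatter), so the three compounds cannot be separated on these numbers.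

Compound 4, `COc1ccc2ncc(S(=O)(=O)c3ccc(OC)c(OC)c3)c(N3CCC(C)CC3)c2c1`, has not yet been measured. It differs from compound 1 at a different place than any of the measured steps: 3,4-dimethoxyphenyl in place of 3-chloro-4-methylphenyl on a sulfonyl sulfur. The three measured steps each exchange a single group on the aromatic carbon of the shared core and were all within the scatter, which says nothing about exchanging the whole aryl group on the sulfonyl sulfur. Going by the values given here, the data give no step of this kind, so the expectation rests on the change itself being larger than those measured. Compound 4 is therefore estimated at 65%, with a range from 30% to 92%, which would mean an expected step of a number 20 percentage points lower from compound 1 to compound 4 (beyond the scatter), most likely downward but uncertain in size.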

Compound 4, a percentage reported as inhibition, at one concentration (the size of the read-out at that concentration, not a potency): -3%
Beside the measured number, compound 4's estimate is 68 percentage points above it, outside the stated range (below it).
By their numbers in this assay, from the lowest: compound 4; then compounds 3, 1 and 2 (each within the scatter of the next).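

Exchanging 3-chloro-4-methylphenyl for 3,4-dimethoxyphenyl on a sulfonyl sulfur gives a number 88 percentage points lower from compound 1 to compound 4 (beyond the scatter) in this assay, so compound 4 shows essentially no inhibition in this test. The earlier exchanges on an aromatic carbon of the shared core all stayed within the scatter, so among these compounds only the change of aryl group on the sulfonyl sulfur separates one number from the others. No measurement available here accounts for the size of this loss.

The exchange replaces the chloro and the methyl together, so the compounds shown leave open whether a single methoxy would be enough to produce the loss. They also leave open how an unsubstituted phenyl, a fluorophenyl or a pyridyl group on the sulfonyl sulfur would compare with these two aryl groups.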